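The source may report more compounds than this note shows. Statements on the series, on what has been measured and on what is new or still open speak of the compounds shown alone.

Measured compounds:
compound 1, `COc1cc(-c2cc3c(O)nc(C)nc3cc2C(C)C)ccc1Cl`: 14 nM
compound 2, `CCc1nc(O)c2cc(-c3ccc(Cl)cc3)c(C(C)C)cc2n1`: a limit of the assay, > 1000 nM
compound 3, `COc1cc(Cl)cc(-c2cc3c(O)nc(C)nc3cc2C(C)C)c1`: 100 nM

In a functional assay for inhibition of transient receptor potential cation channel subfamily V member 1 (Homo sapiens), read by fluorescence and calcium flux (a lower number here means a stronger inhibitor, a higher number a weaker inhibitor), compound 1 gives 14 nM, the lowest of the two numbers recorded. Compound 3, in this assay, gives 100 nM, a gap that lies beyond the usual scatter. For compound 2 this assay reports only a limit, > 1000 nM, at which one of the three values sits (the limit of > 1000 nM in this assay, at which 1 of the 3 values shown sits).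

The step of interest leads from compound 1 to compound 4, `CCOc1cc(-c2cc3c(O)nc(C)nc3cc2C(C)C)ccc1Cl`, which has not yet been measured. The change is small: methyl in place of hydrogen on a saturated chain carbon bound to an oxygen on an aromatic ring; read one bond further out, methoxy becomes ethoxy. Going by the values given here, none of the measured pairs differ in just this place, so there is no measured step to lean on. Given that compound 1 gives 14 nM, compound 4 is expected to stay close to it, with a step of a 1.8-fold higher number from compound 1 to compound 4 (0.25 log units; within the scatter) that is estimated to fall within the scatter or only slightly toward a weaker inhibitor. The estimate for compound 4 in this assay is 25 nM, expected to lie between 8 nM and 80 nM.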

Compound 4, half-maximal inhibitory concentration: 12 nM
Beside the measured number, compound 4's estimate is 2.1-fold (0.32 log units) above it, and the stated range covers the measured number.
By their numbers in this assay, from the lowest: compounds 4 and 1 (each within the scatter of the next); then compound 3. At a limit, above all of these: compound 2.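

In this assay, the change from methoxy to ethoxy leaves the potency of the series intact, with a 1.2-fold lower number from compound 1 to compound 4 (0.07 log units; within the scatter). Going by these compounds alone, this is the first single-place comparison at this position, and it shows that a methyl can enter on the saturated chain carbon bound to an oxygen on an aromatic ring without a shift beyond the scatter. Nothing shown here gives a reason for this result.

On these data alone, whether the position also accepts a longer chain such as propoxy, or a chain ending in an amine or a carboxylic acid, remains open. As far as these compounds go, it is also open whether methoxy to ethoxy would read the same in the related compound 3, which gives 100 nM in this assay.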